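The source may report more compounds than this note shows. Statements on the series, on what has been measured and on what is new or still open speak of the compounds shown alone.

Measured in a functional assay on DU-145 cells (Homo sapiens) for cytotoxicity, read by MTT assay; a higher number here means a weaker inhibitor, a lower number a stronger inhibitor:
- Compound 1 `CC(=O)OCCO[C@H](CC=C(C)C)C1=CC(=O)c2c(O)ccc(O)c2C1=O`: 15500 nM
- Compound 2 `CC(C)=CC[C@@H](OCCO)C1=CC(=O)c2c(O)ccc(O)c2C1=O`: 9900 nM
- Compound 3 `CC(C)=CC[C@@H](OC(=O)C1CCCOC1)C1=CC(=O)c2c(O)ccc(O)c2C1=O`: 29700 nM

Compound 3 has the highest number of the three, but the data show a 1.9-fold higher number from compound 1 to compound 3 (0.28 log units; within the scatter) and a 3.0-fold higher number from compound 2 to compound 3 (0.48 log units; beyond the scatter). Compound 4 `CCC(O)(CC)CC(=O)O[C@H](CC=C(C)C)C1=CC(=O)c2c(O)ccc(O)c2C1=O` differs from compound 3 in one place: 2-ethyl-2-hydroxybutyl in place of oxan-3-yl on a carbonyl carbon, with 2-ethyl-2-hydroxybutyl in place of oxan-3-yl on a carbonyl carbon.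

For the measured compounds named here, no measured step makes this exact swap. The nearest guide is compound 2, a hydroxy-bearing compound at 9900 nM, and the data also show a 1.6-fold lower number from compound 1 to compound 2 (0.19 log units; within the scatter). A small drop within the scatter is therefore expected in this assay, an estimated 1.7-fold lower number from compound 3 to compound 4 (0.22 log units; within the scatter). For compound 4 the estimate is 18000 nM, with an expected range of 7000 nM to 40000 nM.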

Compound 4, half-maximal inhibitory concentration: 67000 nM
The estimate for compound 4 lay 3.7-fold (0.57 log units) below the measured number; measured number outside the range, above it.
By their numbers in this assay, from the lowest: compounds 2, 1 and 3 (each within the scatter of the next, the first and the last beyond it); then compound 4.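

In this assay the open 2-ethyl-2-hydroxybutyl in place of oxan-3-yl on the carbonyl carbon gives a 2.3-fold higher number from compound 3 to compound 4 (0.35 log units; beyond the scatter) and so shows that this position still responds to a change beyond the carbonyl. Against the two compounds with no carbonyl at this oxygen, a 6.8-fold higher number from compound 2 to compound 4 (0.83 log units; beyond the scatter) and a 4.3-fold higher number from compound 1 to compound 4 (0.64 log units; beyond the scatter) are both larger than any earlier step, so a hydroxy group on this chain did not bring back the lower number of compound 2. Nothing at hand explains this rise. From the compounds shown here alone, whether an amine or a carboxylic acid on this chain would move the number in either direction stays open.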